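A few compounds are considered here, and "the series" means these few. Any claim that something is new, unique, unknown or untested is made for them only; others in the source may bear on it.

Compound 1 `O=C(NCc1ccc(F)cc1)c1nc(Br)c2cccnc2c1NCCCNc1c(C(=O)NCc2ccc(F)cc2)nc(Br)c2cccnc12`: > 20000 nM
Compound 2 `O=C(NCc1ccc(F)cc1)c1nc(Br)c2cccnc2c1NCc1ccccc1`: > 20000 nM
Compound 3 `C[C@@H](CO)Nc1nc(C(=O)NCc2ccc(F)cc2)c(O)c2ncccc12`: "not determined" (no result reported)

Three compounds have been put through a functional assay on HCT-116 cells (Homo sapiens) for cytotoxicity, read by MTT assay, with a stated time of 72 h; a higher number here means a weaker inhibitor, a lower number a stronger inhibitor. For compound 1 the reported value of > 20000 nM is a limit of the assay, not a number. For compound 2 the reported value of > 20000 nM is likewise a limit rather than a number. For compound 3 the outcome in this assay is "not determined" (no result reported). Going by the values given here, compound 2 therefore stands at the limit of > 20000 nM in this assay, at which 2 of the 3 values shown sit, and no step between two measured compounds can be drawn from these data.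

Compound 4 `CS(=O)(=O)Oc1c(C(=O)NCc2ccc(F)cc2)nc(Br)c2cccnc12` has not yet been measured. It differs from compound 2 in one place: (methylsulfonyl)oxy in place of benzylamino on an aromatic carbon. With compound 2 known only as a limit, nothing measured here tells how large a change in this assay this replacement brings. Compound 4 is expected to remain weak, so the step of an at least 1.3-fold lower number from compound 2 to compound 4 (0.12 log units; that floor lies within the scatter) is estimated to be none beyond the scatter. Compound 4 is thus estimated at 15000 nM, within a range from 3000 nM to 40000 nM.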

Compound 4, half-maximal inhibitory concentration: > 20000 nM
Compound 4: no number, only a limit; the forecaster's own chance of this, stated with the estimate: 60%; at least 1.3-fold (0.12 log units) between middle value and limit.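

Going by these compounds alone, compound 2 and compound 4 are both reported only as limits in this assay, not as numbers, so no step between them can be read. The compounds shown leave open whether (methylsulfonyl)oxy in place of benzylamino changes cytotoxicity at all.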